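The source may hold more compounds than are shown below. What is called first, only, known or untested is meant among the compounds shown, and "the series" means these compounds.

Series notes on the shared core of compound 1 `CCCCCC/C=C\Cc1c(C)[nH]c2ccccc2c1=O`. In an ADME assay on J774 cells (Mus musculus) for cytotoxicity (a lower number here means that less compound is needed, a higher number that more compound is needed for the effect), compound 1 gives 48500 nM. For compound 2 `CCCCCCCc1c(C)[nH]c2cc(OC)c(Cl)cc2c1=O` the result in this assay is a limit, > 37100 nM. For compound 3 `CCCCCCCCCc1c(C)[nH]c2cc(OC)c(Cl)cc2c1=O` the result in this assay is likewise a limit, > 28700 nM. The step that the two limits leave unreadable from compound 2 to compound 3 is unreadable; both of its ends are limits, the limit of > 37100 nM in this assay, at which 1 of the 3 values shown sits, and (the limit of > 28700 nM in this assay, at which 1 of the 3 values shown sits). Compound 2 thus stands only at a limit in this assay, and one further value shown is a limit as well.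

Compound 4 `CCCCC#Cc1c(C)[nH]c2cc(OC)c(Cl)cc2c1=O` differs from compound 2 by hex-1-yn-1-yl in place of heptyl on an aromatic carbon. Among the measured compounds shown here, the only measured step on this chain, a step that the two limits leave unreadable from compound 2 to compound 3, has no readable size, so no direction in this assay can be drawn from it. Compound 4 is expected near 45000 nM, within 20000 nM to 100000 nM. The expected step that the limit leaves unreadable from compound 2 to compound 4 stays within the scatter, and a limit rather than a number is a fair possibility.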

Compound 4, half-maximal effective concentration: 15000 nM
Estimate against measurement, compound 4: 3.0-fold (0.48 log units) above; the whole stated range lies above it.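

In this assay, among the compounds shown here, hex-1-yn-1-yl in place of heptyl on this aromatic carbon gives the one readable step so far: an at least 2.4-fold lower number from compound 2 to compound 4 (0.39 log units; beyond the scatter). The number therefore responds to the group at this position, which the two limits of compound 2 and compound 3 could not show, and it moves toward less compound being needed. The true size of the step may be larger, because compound 2 stands only at a limit: the limit of > 37100 nM in this assay, at which 1 of the 4 values shown sits.

The compounds shown leave open whether the triple bond or the change in chain length carries the step. As far as these compounds go, how an amine, a carboxylic acid or a longer alkynyl chain on this aromatic carbon would read also stays open.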